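Dropping a methyl from the anilide ring of compound 1

The source may report more compounds than this note shows. Statements on the series, on what has been measured and on what is new or still open speak of the compounds shown alone.

Measured so far:
compound 1, `Cc1ccc(NC(=O)CSc2nccn2-c2cccc3ccccc23)c(Br)c1`: 29400 nM
compound 2, `Cc1ccc(-n2ccnc2SCC(=O)Nc2ccc(C)cc2Br)cc1`: 80800 nM
compound 3, `O=C(CSc1nccn1-c1ccc(Cl)cc1)Nc1ccccc1F`: > 345000 nM

In an ADME assay on MT4 cells (Homo sapiens) for cytotoxicity, read by MTT assay (a lower number here means that less compound is tolerated, a higher number that more compound is tolerated), compound 1 gives 29400 nM, the lowest of the two numbers recorded, so it is the least well tolerated of the compounds that returned a number. Its nearest neighbour is compound 2, whose value in this assay is 80800 nM, a gap that lies beyond the scatter. Compound 3 returned only a limit in this assay, > 345000 nM, not a number.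

Compound 4, `O=C(CSc1nccn1-c1cccc2ccccc12)Nc1ccccc1Br`, has not yet been measured in this assay. It differs from compound 1 in one place: hydrogen in place of methyl on an aromatic carbon. Within the data shown here, no pair of measured compounds shares this difference, so there is no measured step to lean on. A change of a single carbon at that place is expected to move the number little, with any shift more likely toward a higher number than a lower one. The estimate for compound 4 is therefore 40000 nM, within 15000 nM to 120000 nM, which means an expected step of a 1.4-fold higher number from compound 1 to compound 4 (0.13 log units; within the scatter).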

Compound 4, half-maximal cytotoxic concentration: 30500 nM
Beside the measured number, compound 4's estimate is 1.3-fold (0.12 log units) above it; low and high end bracket the measured number.
By their numbers in this assay, from the lowest: compounds 1 and 4 (each within the scatter of the next); then compound 2. At a limit, above all of these: compound 3.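

In this assay, the step of a 1.0-fold higher number from compound 1 to compound 4 (0.02 log units; within the scatter) lies within the scatter. This is the first comparison among these compounds that changes only one place, and it shows that hydrogen in place of methyl on this aromatic carbon, para to a large group and meta to a bromo group, leaves no readable difference in cytotoxicity on the core of compound 1. The data shown hold nothing that would explain this outcome.

The compounds shown leave open whether an amine, a carboxylic acid or a longer chain on this same carbon would also leave the number in place. They also leave open whether the change from 2-bromo-4-methylphenyl to 2-bromophenyl would read the same on the core of compound 2.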